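Iodo to Hydroxy on a Shared Core: Expected Potency

The source may report more compounds than this note shows. Statements on the series, on what has been measured and on what is new or still open speak of the compounds shown alone.

Measured compounds:
compound 1, `CC(C)[C@H]1CC[C@@]2(CO2)[C@H]2C(=O)OCC(C(=O)OCc3ccc(-c4ccc([N+](=O)[O-])cc4)o3)=C[C@H]12`, 3600 nM
compound 2, `CC(C)[C@H]1CC[C@@](O)(CI)[C@H]2C(=O)OCC(C(=O)O)=C[C@H]12`, 10100 nM

In a functional assay on WM 266-4 cells (Homo sapiens) for inhibition, with a stated time of 72 h (a lower number here means a stronger inhibitor, a higher number a weaker inhibitor), compound 2 gives the higher of the two numbers, and compound 1 lies a good way lower, a gap beyond the usual scatter. Compound 3, `CC(C)[C@H]1CC[C@@](O)(CO)[C@H]2C(=O)OCC(C(=O)O)=C[C@H]12`, differs from compound 2 by one change: hydroxy in place of iodo on a saturated chain carbon bound to a saturated ring carbon. For the measured compounds named here, no measured pair shows this change, so the data give no direction for it. The step is expected to be small, a 1.2-fold higher number from compound 2 to compound 3 (0.07 log units; within the scatter), within the scatter. Compound 3 is therefore estimated at 12000 nM, in a range from 4000 nM to 40000 nM.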

Compound 3, half-maximal inhibitory concentration: > 32000 nM
Compound 3: a limit, no number (the forecaster's own chance of this, stated with the estimate: 25%); middle value at least 2.6-fold (0.42 log units) away from the limit.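

Putting hydroxy in place of iodo on a saturated chain carbon bound to a saturated ring carbon gives, in this assay, an at least 3.1-fold higher number from compound 2 to compound 3 (0.50 log units; beyond the scatter). This position therefore responds to the change, and the iodomethyl form is the stronger inhibitor of this pair. Compound 3 carries a limit of the assay and not a number, so only a minimum size for the step can be read: the limit of > 32000 nM in this assay, at which 1 of the 3 values shown sits.

The compounds shown leave open whether the drop follows from losing the iodine or from gaining the hydroxy. They also leave open how a bromine or an amine on the same carbon would compare.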